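Swapping a Halogenated Benzyl Group on a Shared Core

The source may hold more compounds than are shown below. What is called first, only, known or untested is meant among the compounds shown, and "the series" means these compounds.

Measured so far:
compound 1 `COc1ccc(C2N=C(SCc3ccc(F)cc3)NC(C)=C2C(=O)Nc2ccc(F)cc2)cc1OC` gives 15.4%
compound 2 `CC1=C(C(=O)Nc2ccc(F)cc2)C(c2ccc([N+](=O)[O-])cc2)N=C(SCc2ccc(Cl)cc2)N1` gives 16.9%
compound 3 `CC1=C(C(=O)Nc2ccc(Br)cc2)C(c2ccc(Cl)cc2Cl)N=C(SCc2ccccc2Cl)N1` gives 16.4%

All three numbers come from a functional assay on the whole organism (artery, strain albino) with Rattus norvegicus as the target, with a stated time of 900 min, at a dose of 10 mg/kg by the oral route; on this read-out lower numbers stand for less inhibition and higher numbers for more inhibition at the one dose given (going by the name of the read-out). On these numbers compound 3 stands second highest of the three, yet its gap to compound 2 and its gap to compound 1 both lie within the usual scatter, so the three compounds cannot be told apart on this read-out. Within the data shown here, no two measured compounds differ in a single place, so no measured step is available to guide the next one.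

Compound 4 `CC1=C(C(=O)Nc2ccc(Br)cc2)C(c2ccc(Cl)cc2Cl)N=C(SCc2ccc(F)cc2)N1` is the unmeasured compound. It differs from compound 3 in one place: 4-fluorophenyl in place of 2-chlorophenyl on a saturated chain carbon bound to a sulfur. Compound 1 already carries a 4-fluorobenzyl group on its sulfur and gives a number in the same band as compound 3, which is the only hint the data offer.

The step of a number 0.4 percentage points lower from compound 3 to compound 4 (within the scatter) is therefore expected to be small, with no direction beyond the scatter. Compound 4 is expected to give about 16%, with a range from 8% to 24%.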

Compound 4, a percentage reported as inhibition, in the whole organism at one dose (the size of the read-out at that dose, not a potency): 23.1%
For compound 4 the middle estimate is 7.1 percentage points below the measured one; the measured number falls inside the stated range.
By their numbers in this assay, from the lowest: compounds 1, 3, 2 and 4 (each within the scatter of the next).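

Among these compounds, this is the only pair here that differs in one place, so it gives the first direct look at the group on the sulfur: in this assay, replacing 2-chlorobenzyl with 4-fluorobenzyl gives a number 6.7 percentage points higher from compound 3 to compound 4 (within the scatter). At this one dose, the read-out therefore does not separate the two groups, and this position accepts either without a change that can be told from the scatter. Nothing available explains this result.

The swap alters both the halogen and its place on the ring, so this single pair cannot show which of the two matters, if either does, and 4-chlorobenzyl on the same core would help to separate them. Also open, from the compounds shown here alone, is how the read-out would respond to a plain benzyl group, with no halogen, or to a longer chain on the sulfur.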